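This account rests on a few compounds, and the source may have more. Where it says the series, first, only, none or still open, it means among the compounds named here.

Measured so far: compound 2 `C=CC(=O)NCc1coc(-c2c(N)ncnc2Nc2ccc(Oc3ccc(F)cc3)c(Cl)c2)n1` and compound 1 `C=CC(=O)NCc1coc(-c2c(N)ncnc2Nc2ccc(OCc3cccc(F)c3)c(Cl)c2)n1`. In an in vitro ADME assay on microsomes from liver (Rattus norvegicus) for metabolic stability, tested at 5 uM (on this read-out higher numbers stand for a longer-lived compound and lower numbers for a shorter-lived compound), compound 2 gives 1.1 h, the higher of the two numbers; compound 1 gives 0.483 h. Going by the values given here, the one step known, a 2.3-fold higher number from compound 1 to compound 2 (0.36 log units; beyond the scatter), was modest.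

Compound 3 `C=CC(=O)NCc1coc(-c2c(N)ncnc2Nc2ccc(F)c(Cl)c2)n1` differs from compound 2 by fluoro in place of 4-fluorophenoxy on an aromatic carbon. Among the compounds with values here, no measured step covers this change; the step from compound 1 to compound 2 concerned only the group on the oxygen, not its removal, so it offers limited guidance. For compound 3 the step of a 1.2-fold higher number from compound 2 to compound 3 (0.07 log units; within the scatter) is expected to stay near the scatter, and the estimate is 1.3 h, with a range from 0.5 h to 3.5 h.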

Compound 3, half-life: 0.4 h
For compound 3 the middle estimate is 3.3-fold (0.51 log units) above the measured one, and the stated range ends above it.
By their numbers in this assay, from the lowest: compounds 3 and 1 (each within the scatter of the next); then compound 2.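

On this aromatic carbon, ortho to a chloro group, fluoro in place of 4-fluorophenoxy gives in this assay a 2.8-fold lower number from compound 2 to compound 3 (0.44 log units; beyond the scatter), so the large group is not tied to a shorter half-life here. Fluoro in place of (3-fluorobenzyl)oxy gives only a 1.2-fold lower number from compound 1 to compound 3 (0.08 log units; within the scatter), so among these compounds, replacing the large group changes the number beyond the scatter only when it is 4-fluorophenoxy. Nothing presented here accounts for this difference.

Going by these compounds, it remains open whether an unsubstituted phenoxy, a methoxy group or an amine on this carbon would give a number nearer that of compound 2 or that of compound 3.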